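Changing the Group on the Sulfonyl Sulfur

A few compounds are considered here, and "the series" means these few. Any claim that something is new, unique, unknown or untested is made for them only; others in the source may bear on it.

Measured so far:
compound 1 `CC(C)S(=O)(=O)NC(=O)c1ccc(Nc2nc(NC3(c4ccc(Cl)cc4)CC3)nc(OCC(F)(F)F)n2)cc1`: 100%
compound 2 `CC(C)(C)NC(=O)NCCS(=O)(=O)NC(=O)c1ccc(Nc2nc(NC3(c4ccc(Cl)cc4)CC3)nc(OCC(F)(F)F)n2)cc1`: 96%

In an ADME assay on microsomes from liver (Homo sapiens) for metabolic stability, with a stated time of 10 min (on this read-out higher numbers stand for a more stable compound and lower numbers for a less stable compound), compound 1 gives 100%, the highest of the two numbers, with compound 2 nearest. Among the measured compounds shown here, the only measured step, a number 4 percentage points lower from compound 1 to compound 2 (within the scatter), changes the same place as the step to compound 3 `CC(=O)NCCS(=O)(=O)NC(=O)c1ccc(Nc2nc(NC3(c4ccc(Cl)cc4)CC3)nc(OCC(F)(F)F)n2)cc1`, which carries 2-acetamidoethyl in place of isopropyl on a sulfonyl sulfur. Since that related step stayed within the scatter, no change beyond the scatter is expected here, and a number 3 percentage points lower from compound 1 to compound 3 (within the scatter) is the estimated step. Compound 3 is therefore expected at 97%, between 88% and 100%.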

Compound 3, percent of the compound remaining: 95%
Beside the measured number, compound 3's estimate is 2 percentage points above it; measured number inside the range.
By their numbers in this assay, from the lowest: compounds 3, 2 and 1 (each within the scatter of the next).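

Two different chains now sit on the sulfonyl sulfur in this assay: 2-acetamidoethyl in place of isopropyl gives a number 5 percentage points lower from compound 1 to compound 3 (within the scatter) and adds one hydrogen-bond donor and one acceptor. At the far end of the chain, methyl in place of (tert-butyl)amino on a carbonyl carbon gives a number 1 percentage points lower from compound 2 to compound 3 (within the scatter), so this second change at the chain's end also stays within the scatter. Nothing available here explains these results.

Still open, going by these compounds, is how a chain ending in an amine or a carboxylic acid, or a longer chain, would behave in this assay.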